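Cytotoxicity limits in the carbonyl series: butoxy to 4-methylphenyl

The source may report more compounds than this note shows. Statements on the series, on what has been measured and on what is new or still open speak of the compounds shown alone.

In an ADME assay on Vero cells (Chlorocebus sabaeus) for cytotoxicity, read by resazurin assay, with a stated time of 3 days (a higher number here means a weaker inhibitor, a lower number a stronger inhibitor), compound 3 `CCCCOC(=O)Nc1cc2nc(C3CCCCC3)[nH]c2cc1N(CC)CC` gives > 100 ug/mL, which is a limit and not a number. Compound 2 `CCN(CC)c1cc2[nH]c(C3CCCCC3)nc2cc1NC(=O)c1ccc(OC(F)F)cc1` gives > 100 ug/mL, again a limit. Compound 1 `CCN(CC)c1cc2[nH]c(C3CCCCC3)nc2cc1NC(=O)c1ccc(N(C)C)cc1` has no usable result, its entry reading "not determined" (no result reported). What is known so far amounts to the limit of > 100 ug/mL in this assay, at which 2 of the 3 values shown sit.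

The next compound is compound 4 `CCN(CC)c1cc2[nH]c(C3CCCCC3)nc2cc1NC(=O)c1ccc(C)cc1`, and the change from compound 3 is 4-methylphenyl in place of butoxy on a carbonyl carbon. In words, 4-methylphenyl stands in place of butoxy on a carbonyl carbon, so an aromatic ring returns to the position that holds 4-(difluoromethoxy)phenyl in compound 2.

Among the measured compounds shown here, one measured step bears on this change, as it exchanges the same kind of groups at that carbonyl carbon: a step that the two limits leave unreadable from compound 2 to compound 3. It gives no size to carry over, and it offers no sign that either group lowers the reading in this assay. No shift in either direction beyond the usual scatter is therefore expected, and another report as a limit is the likeliest outcome. The estimated step that the limit leaves unreadable from compound 3 to compound 4 is expected to stay within that scatter. Compound 4 is expected at about 150 ug/mL, with an estimated range from 60 ug/mL to 300 ug/mL.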

Compound 4, half-maximal inhibitory concentration: > 100 ug/mL
Compound 4 ended at the assay's limit; the forecaster's own chance of this, stated with the estimate: 75%; the middle value lies beyond the limit too.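

Compound 4 returns a limit and not a number in this assay, so its steps from compound 2 and compound 3 cannot be read; all three stand at the same limit: the limit of > 100 ug/mL in this assay, at which 3 of the 4 values shown sit.

The compounds shown leave open whether any group on the carbonyl carbon gives a number rather than a limit in this assay.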